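This account rests on a few compounds, and the source may have more. Where it says the series, first, only, none or still open, it means among the compounds named here.

Three compounds share one core and differ only in the small group on the saturated chain carbon of the amide. Compound 1 `O=C(CBr)Nc1ccc(C(=O)/C=C/c2ccc(Cl)cc2)cc1` carries bromo there, compound 2 `O=C(CO[N+](=O)[O-])Nc1ccc(C(=O)/C=C/c2ccc(Cl)cc2)cc1` carries nitrooxy in its place, and compound 3 `CC(Br)C(=O)Nc1ccc(C(=O)/C=C/c2ccc(Cl)cc2)cc1` carries the 1-bromoethyl group. In a functional assay on the whole organism (strain albino) for inhibition, with Rattus norvegicus as the target, read by paw edema, with stated times of 30 min and 5 h, at a dose of 100 mg/kg by the oral route (on this read-out higher numbers stand for more inhibition at the one dose given (going by the name of the read-out) and lower numbers for less inhibition), compound 1 gives 54%, compound 2 gives 60% and compound 3 gives 50%. On the bare numbers compound 3 stands lowest of the three, but the gaps are small: a number 4 percentage points lower from compound 1 to compound 3 (within the scatter) and a number 10 percentage points lower from compound 2 to compound 3 (within the scatter), so no real order among them can be claimed.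

Compound 4 `CC(O[N+](=O)[O-])C(=O)Nc1ccc(C(=O)/C=C/c2ccc(Cl)cc2)cc1` completes the set: nitrooxy in place of bromo on a saturated chain carbon bound to a carbonyl carbon and a saturated chain carbon. The same difference, cut one bond further out, reads 1-bromoethyl to 1-(nitrooxy)ethyl. Within the data shown here, one measured step bears directly on it, the exchange of bromo for nitrooxy seen between compound 1 and compound 2, where a number 6 percentage points higher from compound 1 to compound 2 (within the scatter). The step from compound 3 to compound 4 is therefore expected to be a number 5 percentage points higher from compound 3 to compound 4 (within the scatter), a shift within the scatter rather than a real gain. Compound 4 is estimated at 55%, with a range from 42% to 68%.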

Compound 4, a percentage reported as inhibition, in the whole organism at one dose (the size of the read-out at that dose, not a potency): 56%
For compound 4 the middle estimate is 1 percentage points below the measured one; the range from low to high includes it.
By their numbers in this assay, from the lowest: compounds 3, 1, 4 and 2 (each within the scatter of the next).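

In this assay, the exchange of bromo for nitrooxy now appears on a second core, where the step reads a number 6 percentage points higher from compound 3 to compound 4 (within the scatter), and it matches the first case: the same change on two cores in this assay, a number 6 percentage points higher (within the scatter) from compound 1 to compound 2 and a number 6 percentage points higher (within the scatter) from compound 3 to compound 4, 0 percentage points apart, within the scatter of two such steps. Adding methyl on the saturated chain carbon also repeats, this time with nitrooxy in place of bromo, where the step reads a number 4 percentage points lower from compound 2 to compound 4 (within the scatter): the same change on two cores in this assay, a number 4 percentage points lower (within the scatter) from compound 1 to compound 3 and a number 4 percentage points lower (within the scatter) from compound 2 to compound 4, 0 percentage points apart, within the scatter of two such steps. With both changes together the step reads a number 2 percentage points higher from compound 1 to compound 4 (within the scatter), so the two changes combine without either visibly altering the other, though every step here stays within the scatter and neither change is shown to have a real effect.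

On these data alone, it remains open whether an amine, a carboxylic acid or a longer chain on this carbon would move the read-out beyond the scatter. Also open, as far as these compounds go, is how these four compounds compare at any other dose.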